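The source may report more compounds than this note shows. Statements on the series, on what has been measured and on what is new or still open speak of the compounds shown alone.

Two compounds sharing a core have numbers in a functional assay on DU-145 cells (Homo sapiens) for cytotoxicity, read by ELISA, with a stated time of 2 days; a higher number here means a weaker inhibitor, a lower number a stronger inhibitor. Compound 1 (`Oc1ccccc1-c1cc(-c2ccccc2)cc(-c2ccccc2O)n1`) gives 8000 nM, and compound 2 (`Oc1cccc(-c2cc(-c3ccccc3)cc(-c3cccs3)n2)c1`) gives 18900 nM. Compound 2 therefore stands highest of the two, making it the weaker inhibitor of the pair, and the gap between them lies beyond the usual scatter of repeated measurements.

Compound 3 (`Oc1cccc(-c2cc(-c3ccccc3)cc(-c3ccco3)n2)c1`) has yet to be measured in this assay. It differs from compound 2 in one place, with furan-2-yl in place of thiophen-2-yl on an aromatic carbon. Among the measured compounds shown here, the measured compounds include no pair that differs in one place, so the data give no direct guide to this exchange. The two groups match in everything counted except the hetero atom, so no step beyond the scatter is expected in this assay, and no direction is clearly favoured. The expectation for compound 3 therefore starts from compound 2 at 18900 nM. The estimated change is a 1.2-fold lower number from compound 2 to compound 3 (0.07 log units; within the scatter). For compound 3, the expected value is 16000 nM, with an estimated range from 7000 nM to 40000 nM.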

Compound 3, half-maximal inhibitory concentration: 14400 nM
Compound 3: middle estimate off by 1.1-fold (0.05 log units), on the high side; the range from low to high includes it.
By their numbers in this assay, from the lowest: compounds 1, 3 and 2 (each within the scatter of the next, the first and the last beyond it).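

Among the compounds shown here, the exchange of thiophen-2-yl for furan-2-yl provides the first direct reading of a single change in this assay, at the aromatic carbon next to the ring nitrogen, and it amounts to a 1.3-fold lower number from compound 2 to compound 3 (0.12 log units; within the scatter). At this position, with the 3-hydroxyphenyl and phenyl groups held constant, replacing the sulfur of the five-membered aromatic ring with oxygen produces no step beyond the scatter, so compound 2 and compound 3 cannot be placed in order. Nothing measured alongside these compounds accounts for this result.

The compounds shown leave open how this position responds to a group other than these two five-membered aromatic rings: an amine, a carboxylic acid or a longer alkyl chain might give a step beyond the scatter or none at all. Also open, from the compounds shown here alone, is what the hydroxyl group on the 3-hydroxyphenyl group contributes, and compound 1 cannot settle this, as it differs from compound 2 and compound 3 in more than one place.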